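Methoxy for methyl on the cyclohexyl ring: cytotoxicity

A few compounds are considered here, and "the series" means these few. Any claim that something is new, unique, unknown or untested is made for them only; others in the source may bear on it.

Compound 1 `CCC1=C(C(=O)CC2CCCC2)[C@H](c2ccc(O)c(Cl)c2)NC(=O)N1` gives in an ADME assay on cells (Homo sapiens) for cytotoxicity; on this read-out higher numbers stand for lower toxicity in this test and lower numbers for higher toxicity in this test > 10000 nM, a limit of the assay.
Compound 2 `CCC1=C(C(=O)CC2CCC(C)CC2)[C@H](c2ccc(O)c(Cl)c2)NC(=O)N1` gives in this assay > 10000 nM, which is again a limit of the assay.

Compound 2 thus stands at the top end of what is shown, and the two values shown sit together at one place: the limit of > 10000 nM in this assay, at which 2 of the 2 values shown sit. The one step measured among these compounds, a step that the two limits leave unreadable from compound 1 to compound 2, cannot be read in size because both of its ends are limits.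

Compound 3 `CCC1=C(C(=O)CC2CCC(OC)CC2)[C@H](c2ccc(O)c(Cl)c2)NC(=O)N1` differs from compound 2 by methoxy in place of methyl on a saturated ring carbon. Among the measured compounds shown here, no measured step bears readably on this change, so for compound 3 the step from compound 2 is expected to be a step that the limit leaves unreadable from compound 2 to compound 3, that is, nothing beyond the scatter. Compound 3 is therefore estimated at 15000 nM, within a range from 5000 nM to 50000 nM, most likely reported again only as a limit.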

Compound 3, half-maximal cytotoxic concentration: > 10000 nM
Compound 3: only a limit was reported; the forecaster's own chance of this, stated with the estimate: 80%; the middle value lies beyond the limit too.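

Compound 3, like compound 1 and compound 2, is reported in this assay only as a limit, so no step among these compounds can be read in size: the limit of > 10000 nM in this assay, at which 3 of the 3 values shown sit. The compounds shown leave open how far any of them lies past that limit, and whether methyl and methoxy differ in this assay at all.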